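This account rests on a few compounds, and the source may have more. Where it says the series, first, only, none or still open, it means among the compounds named here.

Measured compounds in a functional assay on MCF7 cells (Homo sapiens) for cytotoxicity, read by MTT assay, with a stated time of 48 h; a higher number here means a weaker inhibitor, a lower number a stronger inhibitor:
Compound 1, `O=C(CSCc1nc2cc([N+](=O)[O-])ccc2[nH]1)c1ccc(Cl)cc1`, gives 2800 nM.
Compound 2, `O=C(CSCc1nc2cc([N+](=O)[O-])ccc2[nH]1)c1ccc(Br)cc1`, gives 1550 nM.
Compound 3, `CCOC(=O)CSCc1nc2cc([N+](=O)[O-])ccc2[nH]1`, gives only a limit of the assay, > 100000 nM.

Compound 3 therefore stands at the edge of what this assay reports: the limit of > 100000 nM in this assay, at which 1 of the 3 values shown sits, so no number is known for it, only that it lies beyond the top of the range. The two steps that lead to compound 3 are both large, an at least 35-fold higher number from compound 1 to compound 3 (1.55 log units; beyond the scatter) and an at least 64-fold higher number from compound 2 to compound 3 (1.80 log units; beyond the scatter), whereas the halogen exchange between the two aryl ketones, a 1.8-fold lower number from compound 1 to compound 2 (0.26 log units; within the scatter), stays within the scatter.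

Compound 4, `N#CCSCc1nc2cc([N+](=O)[O-])ccc2[nH]1`, differs from compound 3 by cyano in place of ethoxycarbonyl on a saturated chain carbon bound to a sulfur. Within the data shown here, none of the measured steps touches this change directly; the only steps that reach compound 3 concern the exchange of an aryl ketone for the ethoxycarbonyl group, and both point to the same end of the range where compound 3 now sits. Since compound 3 gives only a limit, no step size from it to compound 4 can be measured in either direction, and the expectation is that compound 4 remains at that limit, with a number no higher from compound 3 to compound 4 (the limit leaves the size open) being the estimated step. Compound 4 is therefore expected to give about 100000 nM, between 30000 nM and 300000 nM, in this assay.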

Compound 4, half-maximal inhibitory concentration: 27400 nM
The estimate for compound 4 lay 3.6-fold (0.56 log units) above the measured number, and the stated range ends above it.
By their numbers in this assay, from the lowest: compounds 2 and 1 (each within the scatter of the next); then compound 4. At a limit, above all of these: compound 3.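

At the saturated chain carbon bound to a sulfur, the exchange of ethoxycarbonyl for cyano turns a compound without an aryl ketone into one with a measurable number: in this assay compound 4 gives 27400 nM. The change gives an at least 3.6-fold lower number from compound 3 to compound 4 (0.56 log units; beyond the scatter), so among the compounds shown, the absence of the aryl ketone does not in itself place a compound at the limit, as the earlier steps alone might have suggested. This step is a bound and not a full size, because compound 3 stands at a limit of the assay: the limit of > 100000 nM in this assay, at which 1 of the 4 values shown sits.

The compounds shown leave open how this assay would read with a carboxylic acid or a primary amide on this same chain carbon, or with a longer chain ending in the nitrile, so it cannot yet be said what about cyano separates it from ethoxycarbonyl here. They also leave open whether an amine in this place, or a phenyl ketone carrying no halogen, would stand nearer to compound 4 or to the two halogenated aryl ketones.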